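A few compounds are considered here, and "the series" means these few. Any claim that something is new, unique, unknown or untested is made for them only; others in the source may bear on it.

Measured so far in a physicochemical assay for lipophilicity, read by HPLC, at pH 7.5; a higher number here means a more lipophilic compound, a lower number a more polar compound:
- compound 1 `CC[C@@H](Nc1c(C#N)c(-c2ccc(-c3ncccc3C)cc2)nc2cnccc12)C(N)=O`: 2
- compound 2 `CC[C@@H](Nc1c(C#N)c(-c2ccc(-c3cnccc3C)cc2)nc2cnccc12)C(N)=O`: 2

Within the data shown here, compound 2 stands level with compound 1, its only measured neighbour. In this assay compound 2 reads 2. The next structure is compound 3 `CC[C@@H](Nc1c(C#N)c(-c2ccc(-c3cccc(CO)c3)cc2)nc2cnccc12)C(N)=O`, which carries 3-(hydroxymethyl)phenyl in place of 4-methylpyridin-3-yl on an aromatic carbon, para to a large group: 3-(hydroxymethyl)phenyl in place of 4-methylpyridin-3-yl on an aromatic carbon.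

Among the measured compounds shown here, one measured step bears on this place: no change at the digits printed from compound 1 to compound 2 (within the scatter). It exchanged 3-methylpyridin-2-yl for 4-methylpyridin-3-yl, so it gives only limited guidance. For the measured compounds named here, no measured step replaces that ring with a ring of carbon only or introduces hydroxymethyl. The data therefore give no direction for this change, and no move beyond the scatter is expected in this assay, with the range kept wide to reflect the thin evidence. The estimated step is no change at the digits printed from compound 2 to compound 3 (within the scatter). For compound 3 the expected value is 2, with an estimated range from 1.5 to 2.5.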

Compound 3, distribution coefficient: 2
Compound 3: the middle estimate sits on the measured number at the digits printed; measured number inside the range.
By their numbers in this assay, from the lowest: compounds 1, 2 and 3 (each within the scatter of the next).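

In this assay, replacing 4-methylpyridin-3-yl with 3-(hydroxymethyl)phenyl on an aromatic carbon, para to a large group, gives no change at the digits printed from compound 2 to compound 3 (within the scatter) and the matching replacement of 3-methylpyridin-2-yl gives no change at the digits printed from compound 1 to compound 3 (within the scatter) as its outcome. The earlier pair only moved between two methylpyridine groups, whereas this result shows that the position also accepts a six-membered aromatic ring of carbon only, bearing hydroxymethyl and thus a hydrogen-bond donor, with no reading outside the scatter. No supporting measurement is available to account for this flat reading.

From the compounds shown here alone, whether the same flat reading in this assay would hold for a carboxylic acid or an aliphatic amine on this ring remains open, since the groups leaving and entering in the last step carry no net charge. Also open, going by these compounds, is whether a longer chain ending in hydroxyl, in place of hydroxymethyl, or a second hydroxymethyl on the same ring would stay within the scatter of compound 3.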